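The source may report more compounds than this note shows. Statements on the series, on what has been measured and on what is new or still open speak of the compounds shown alone.

Compound 3 `CCN1C(=O)CN(S(=O)(=O)c2ccc(-n3nc(C)cc3C)cc2)C1=S` was tested in a functional assay on the whole organism (blood, strain albino) with Mus musculus as the target, with stated times of 6 days and 4 h, at a dose of 1 mmol/kg by the oral route; on this read-out lower numbers stand for less inhibition and higher numbers for more inhibition at the one dose given (going by the name of the read-out). Compound 3 gives < 1%, which is a limit of the assay rather than a number. Two close relatives give a bearing. Compound 1 `CCN1C(=O)CN(S(=O)(=O)c2ccc(-n3nc(C(=O)O)cc3C)cc2)C1=S` carries a carboxy group on an aromatic carbon where compound 3 carries a methyl. In this assay compound 1 gives < 1%, again a limit. Compound 2 `Cc1cc(C)n(-c2ccc(S(=O)(=O)N3CC(=O)N(Cc4ccccc4)C3=S)cc2)n1` carries a phenyl in place of the methyl on a saturated chain carbon bound to an amide-type nitrogen in a ring, and in this assay compound 2 gives 1%. The step that the two limits leave unreadable from compound 1 to compound 3 cannot be read, and the step of a number no higher from compound 2 to compound 3 (the limit leaves the size open) is no higher. All three values sit at or next to the limit of < 1% in this assay, at which 2 of the 3 values shown sit. Compound 4 `C=CCN1C(=O)CN(S(=O)(=O)c2ccc(-n3nc(C)cc3C)cc2)C1=S` brings the next change at the same place as the step from compound 2: vinyl in place of methyl on a saturated chain carbon bound to an amide-type nitrogen in a ring. Among the compounds with values here, only that step bears on it, and it showed no rise. Compound 4 is therefore expected to stay at the floor, with an estimated 1% between 0% and 10%. The expected step of a number no lower from compound 3 to compound 4 (the limit leaves the size open) has no size beyond the scatter.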

Compound 4, a percentage reported as inhibition, in the whole organism at one dose (the size of the read-out at that dose, not a potency): 4%
Compound 4: middle estimate off by 3 percentage points, on the low side; measured number inside the range.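

In this assay, the change from ethyl to allyl, which puts a double bond outside aromatic rings at this place on the shared core, gives a number at least 3 percentage points higher from compound 3 to compound 4 (that floor lies within the scatter). Setting vinyl in place of phenyl at the same place gives a number 3 percentage points higher from compound 2 to compound 4 (within the scatter), so the methyl, vinyl and phenyl versions cannot be told apart in this assay. The new value therefore adds a third group at this place without lifting the series clear of the bottom of the scale: the limit of < 1% in this assay, at which 2 of the 4 values shown sit.

From the compounds shown here alone, whether an amine or a longer chain at this place would give inhibition clearly beyond the scatter stays open. Also open, going by these compounds, is whether any change at this place can move this assay at all, as every value shown lies close to the limit.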